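The source may hold more compounds than are shown below. What is called first, only, known or untested is meant among the compounds shown, and "the series" means these compounds.

The measured compounds are:

Compound 1, `CCCNC(=O)/N=C(\N)NCCCc1sc(N)nc1C`: 170 nM
Compound 2, `Cc1nc(N)sc1CCCN/C(N)=N/C(=O)NCC(C)C1CCCCC1`: 224 nM
Compound 3, `Cc1ccc(CC(C)CNC(=O)/N=C(\N)NCCCc2sc(N)nc2C)cc1`: 132 nM

All three were tested in a functional assay on HEK293T cells for agonist activity at histamine H2 receptor (Homo sapiens), read by beta-arrestin recruitment; a higher number here means that more compound is needed for the effect, a lower number that less compound is needed. Compound 1 stands second highest of the three numbers, but its neighbours sit close on either side: the step of a 1.3-fold lower number from compound 1 to compound 3 (0.11 log units; within the scatter) and the step of a 1.3-fold higher number from compound 1 to compound 2 (0.12 log units; within the scatter) are both within the scatter, as is the step of a 1.7-fold lower number from compound 2 to compound 3 (0.23 log units; within the scatter). Within this small set, then, nothing separates the three compounds beyond the noise of the measurement.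

Compound 4, `Cc1nc(N)sc1CCCN/C(N)=N/C(=O)Nc1ccccc1`, has not yet been measured. Against compound 1 the change is phenyl in place of propyl on an amide-type nitrogen. For the measured compounds named here, none of the measured steps touches this position: each of them alters a saturated chain carbon bound to two saturated chain carbons, further out along the substituent, and each stays within the scatter. Going by the values given here, the data therefore offer no step that bears directly on exchanging propyl for phenyl on the amide-type nitrogen, and no case where any change moved the number beyond the scatter.

On that basis compound 4 is expected to show no change at the digits printed from compound 1 to compound 4 (within the scatter), that is, no step beyond the scatter. Compound 4 is estimated at 170 nM, within a range from 55 nM to 520 nM to allow for the untested nature of the change.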

Compound 4, half-maximal effective concentration: 3390 nM
Compound 4: the middle estimate sits 20-fold (1.30 log units) below what was measured, and the stated range ends below it.
By their numbers in this assay, from the lowest: compounds 3, 1 and 2 (each within the scatter of the next); then compound 4.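

In this assay, for the compounds shown here, phenyl in place of propyl on the amide-type nitrogen gives a 20-fold higher number from compound 1 to compound 4 (1.30 log units; beyond the scatter), the only step that lies beyond the scatter. The earlier compounds shown here showed only that cyclohexyl or 4-methylbenzyl on a saturated chain carbon bound to two saturated chain carbons leaves the number within the scatter of compound 1; this result shows that the number does respond to a change on the amide-type nitrogen, and that carrying a ring elsewhere in the substituent, as compound 2 and compound 3 do, does not by itself predict what a ring on this nitrogen does. Nothing measured here accounts for the rise.

The compounds shown cannot separate the effect of swapping propyl for a ring from that of having an aromatic ring in particular on this nitrogen, a question that cyclohexyl or benzyl at the same place would address. They also leave open how a substituted phenyl, such as methoxyphenyl or chlorophenyl, would read against the unsubstituted phenyl of compound 4.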